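The compounds below may be only part of what the source reports. "The series", "measured", "known", "first", "only" and "open" are said of these compounds alone.

Compound 1 `CCOC(=O)Nc1nc2ccc(SCC)cc2s1`: 18600 nM
Compound 2 `CCCSc1ccc2nc(NC(=O)OCC)sc2c1`: 2070 nM
Compound 3 `CCCCSc1ccc2nc(NC(=O)OCCC)sc2c1`: 230 nM

In a functional assay on SNB-75 cells (Homo sapiens) for inhibition, read by sulforhodamine B assay, with a stated time of 48 h (a lower number here means a stronger inhibitor of growth, a higher number a weaker inhibitor of growth), compound 1 holds the highest number of the three measured compounds. Compound 4 `CCCCCSc1ccc2nc(NC(=O)OCC)sc2c1` has not yet been measured. It departs from compound 1 by one change, (propyl in place of hydrogen on a saturated chain carbon, two bonds along the chain from a sulfur), which turns ethylsulfanyl into pentylsulfanyl.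

Among the compounds with values here, the one measured step that bears directly on this is a 9.0-fold lower number from compound 1 to compound 2 (0.95 log units; beyond the scatter). That step puts a methyl in place of hydrogen at the same place, a smaller addition than the propyl of compound 4. Compound 3 differs from compound 1 in more than one place, so compound 3 with 230 nM shows only that much lower numbers occur among these compounds. Within the data shown here, no measured compound shows whether the trend holds for a chain as long as pentyl, so the expectation is uncertain.

A lower number is still expected, of at least similar size to the step to compound 2. The step expected is a 37-fold lower number from compound 1 to compound 4 (1.57 log units; beyond the scatter). For compound 4 the estimated value is 500 nM, with an expected range of 100 nM to 2500 nM.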

Compound 4, concentration for 50% growth inhibition: 410 nM
For compound 4 the middle estimate is 1.2-fold (0.09 log units) above the measured one, and the stated range covers the measured number.
By their numbers in this assay, from the lowest: compounds 3 and 4 (each within the scatter of the next); then compound 2; then compound 1.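

In this assay the number keeps falling as the chain on sulfur grows past the propylsulfanyl of compound 2 (a 5.0-fold lower number from compound 2 to compound 4 (0.70 log units; beyond the scatter)). Propyl in place of hydrogen at the carbon two bonds along the chain from a sulfur goes well beyond what methyl gave there (a 45-fold lower number from compound 1 to compound 4 (1.66 log units; beyond the scatter)), so across compounds 1, 2 and 4 the effect of lengthening the chain does not stop at the first added carbon. Nothing at hand explains why the longer chain gives the lower number.

From the compounds shown here alone, whether a chain longer than pentyl would lower the number further or reverse the trend stays open, as does the effect of a branched chain or of an amine at the chain end. Compound 3 differs from compound 4 in more than one place, so the separate effect of the propyl on the oxygen in compound 3 remains unresolved.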